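A One-Carbon Extension Tested on a Weaker Inhibitor

The compounds below may be only part of what the source reports. "The series", "measured", "known", "first", "only" and "open" are said of these compounds alone.

Compound 1 `CCCc1ccc(C/N=C(\S)NCc2ccc(NS(C)(=O)=O)c(F)c2)cc1` and compound 2 `CCCCc1ccc(C/N=C(\S)NCc2ccc(NS(C)(=O)=O)c(F)c2)cc1` share a core and differ in a single place. In an assay for inhibition of transient receptor potential cation channel subfamily V member 1 (Rattus norvegicus), with a stated time of 10 min (a higher number here means a weaker inhibitor, a lower number a stronger inhibitor), compound 1 gives 460 nM, and compound 2 gives 470 nM. The change between them is methyl in place of hydrogen on a saturated chain carbon, three bonds along the chain from an aromatic carbon, and the step it made was a 1.0-fold higher number from compound 1 to compound 2 (0.01 log units; within the scatter).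

Compound 3 `COC(=O)CNc1ccc(C/N=C(\S)NCc2ccc(C(C)(C)C)cc2)cc1F` rests on a different core; the difference between the two cores is not broken down here. In this assay compound 3 gives 3600 nM, the highest of the three numbers and beyond the scatter from both compound 1 and compound 2.

Compound 4 `CCOC(=O)CNc1ccc(C/N=C(\S)NCc2ccc(C(C)(C)C)cc2)cc1F` has not yet been measured in this assay. It differs from compound 3 by methyl in place of hydrogen on a saturated chain carbon bound to an oxygen next to a carbonyl group. This is the same kind of change as that from compound 1 to compound 2, though the place is not the same: there the methyl entered on a saturated chain carbon, three bonds along the chain from an aromatic carbon, whereas here it enters on a saturated chain carbon bound to an oxygen next to a carbonyl group.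

Because the earlier step of a 1.0-fold higher number from compound 1 to compound 2 (0.01 log units; within the scatter) stayed within the scatter, the step from compound 3 to compound 4 is expected to be small, a 1.1-fold lower number from compound 3 to compound 4 (0.05 log units; within the scatter). The expected value for compound 4 in this assay is therefore 3200 nM, estimated to fall between 1500 nM and 7000 nM.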

Compound 4, half-maximal inhibitory concentration: > 30000 nM
Compound 4 ended at the assay's limit; the forecaster's own chance of this, stated with the estimate: 5%; middle value at least 9.3-fold (0.97 log units) away from the limit.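

In this assay compound 4 gives > 30000 nM, which is a limit of the assay and not a number, and the step to it reads an at least 8.3-fold higher number from compound 3 to compound 4 (0.92 log units; beyond the scatter). The same one-methyl change therefore did not carry over unchanged from one core to the other, leaving the number in place on the core of compound 1 while giving a clearly weaker inhibitor on the core of compound 3: the same change on two cores in this assay, a 1.0-fold higher number (0.01 log units; within the scatter) from compound 1 to compound 2 and an at least 8.3-fold higher number (0.92 log units; beyond the scatter) from compound 3 to compound 4, at least 8.1-fold (0.91 log units) apart, beyond the scatter of two such steps This does not show that the core alone sets the outcome, as the methyl enters at a different place in each pair, here on a saturated chain carbon bound to an oxygen next to a carbonyl group, and the true size of the step also stays unknown at the limit: the limit of > 30000 nM in this assay, at which 1 of the 4 values shown sits.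

The compounds shown leave open whether the sharp rise belongs to the ester chain itself, which a propyl ester or a longer chain on the same core could test. They also leave open how a carboxylic acid or an amide in place of the ester would stand in this assay, and whether the methoxycarbonyl to ethoxycarbonyl change behaves the same way on the core of compound 1.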